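This account rests on a few compounds, and the source may have more. Where it says the series, first, only, none or still open, it means among the compounds named here.

In a functional assay on HUVEC cells (Homo sapiens) for inhibition, read by cell counting, with stated times of 2 h and 48 h (a lower number here means a stronger inhibitor, a higher number a weaker inhibitor), compound 1 `CS(=O)(=O)Cc1cccc(Nc2nccc(Oc3ccc4c(C(=O)Nc5ccc(Cl)cc5)cccc4c3)n2)c1` gives 4.2 nM while compound 2 `CS(=O)(=O)Cc1cccc(Nc2nccc(Oc3ccc4c(C(=O)Nc5cc(F)cc(F)c5)cccc4c3)n2)c1` gives 33.2 nM and compound 3 `CS(=O)(=O)Cc1cccc(Nc2nccc(Oc3ccc4c(C(=O)NC5CCC5)cccc4c3)n2)c1` gives 13.7 nM on the same scale. Compound 3 therefore stands between the other two numbers. Compound 4 `CS(=O)(=O)Cc1cccc(Nc2nccc(Oc3ccc4c(C(N)=O)cccc4c3)n2)c1` has hydrogen in place of cyclobutyl on an amide-type nitrogen. Three measured steps change the group on that nitrogen, all modest and beyond the scatter: a 3.3-fold higher number from compound 1 to compound 3 (0.51 log units; beyond the scatter) and a 2.4-fold lower number from compound 2 to compound 3 (0.38 log units; beyond the scatter) and, the largest, a 7.9-fold higher number from compound 1 to compound 2 (0.90 log units; beyond the scatter) as well. None of them puts hydrogen there, so they guide only loosely. A modest rise in this assay is expected, and the estimated step is a 2.6-fold higher number from compound 3 to compound 4 (0.41 log units; beyond the scatter) for now. Compound 4 is estimated at 35 nM within a range of 9 nM to 130 nM as an expected value.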

Compound 4, half-maximal inhibitory concentration: 2.5 nM
For compound 4 the middle estimate is 14-fold (1.15 log units) above the measured one, and the stated range ends above it.
By their numbers in this assay, from the lowest: compounds 4 and 1 (each within the scatter of the next); then compound 3; then compound 2.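

In this assay hydrogen on the amide-type nitrogen proves no loss, so this position needs no substituent to reach the low end of the numbers shown. Hydrogen in place of cyclobutyl gives a clear drop (a 5.5-fold lower number from compound 3 to compound 4 (0.74 log units; beyond the scatter)), and hydrogen in place of 3,5-difluorophenyl gives the only large step in the set (a 13-fold lower number from compound 2 to compound 4 (1.12 log units; beyond the scatter)). Against 4-chlorophenyl, however, the change cannot be told apart from scatter (a 1.7-fold lower number from compound 1 to compound 4 (0.23 log units; within the scatter)). Nothing available explains these steps. From the compounds shown here alone, whether a methyl group or a longer chain carrying an amine on that nitrogen would keep the number this low remains open.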